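Oxadiazine-type series: aryloxypropoxy variation and dihydrofolate reductase inhibition

The compounds below may be only part of what the source reports. "The series", "measured", "known", "first", "only" and "open" are said of these compounds alone.

Measured compounds:
compound 1 `NC1=NC2(CCOCC2)N(OCCCOc2ccc(F)cc2)C(N)=N1` — "not determined" (no result reported)
compound 2 `NC1=NC2(CCOCC2)N(OCCCOc2ccc(Cl)cc2)C(N)=N1` — "not determined" (no result reported)
compound 3 `NC1=NC2(CCOCC2)N(OCCCOc2cccc(Cl)c2Cl)C(N)=N1` — 89.8%

In an assay on isolated protein for inhibition of Dihydrofolate reductase (Homo sapiens), read by spectrophotometry, using NADPH, with stated times of 5 s and 6 min, tested at 50 uM (on this read-out lower numbers stand for a weaker effect and higher numbers for a stronger effect at the one concentration tested), compound 3 gives 89.8%, the only numerical result in the set. For the measured compounds named here, for compound 1 the entry is "not determined" (no result reported) and for compound 2 it is "not determined" (no result reported), so no comparison within the measured compounds is possible and no step between them can be stated.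

Compound 4 `NC1=NC2(CCOCC2)N(OCCCOc2ccccc2Br)C(N)=N1` is yet to be measured in this assay. It differs from compound 3 in one place: 2-bromophenyl in place of 2,3-dichlorophenyl on an oxygen on a saturated carbon. The aryl group on the oxygen on the saturated carbon keeps one halogen rather than two, and the halogen changes from chlorine to bromine.

Going by the values given here, with no step to draw on, the expectation for compound 4 rests on compound 3 alone, whose result of 89.8% sits high on the scale. Compound 4 is expected to remain in the same region, with a step of a number 11.8 percentage points lower from compound 3 to compound 4 (beyond the scatter) that is estimated to lie within or only slightly beyond the scatter, towards a weaker effect. The estimate for compound 4 is 78%, in the range 50% to 95%.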

Compound 4, a percentage reported as inhibition, at one concentration (the size of the read-out at that concentration, not a potency): 85%
Beside the measured number, compound 4's estimate is 7 percentage points below it, within the range that was stated.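

In this assay the exchange of 2,3-dichlorophenyl for 2-bromophenyl on the oxygen on a saturated carbon gives a number 4.8 percentage points lower from compound 3 to compound 4 (within the scatter) at the one concentration tested. At this position, then, an aryl group with a single bromine and one with two chlorines give readings within the scatter of each other, so the second halogen is not needed to keep the read-out high in this pair. Nothing available explains this result or bears on how the two aryl groups compare.

Steps involving compound 1 and compound 2 cannot be read, so the 4-fluoro and 4-chloro aryl groups add nothing here. Still open, on these data alone, is how this position responds to an unsubstituted phenyl, to an aryl group carrying an amine or a carboxylic acid, or to a longer chain in place of the propoxy link.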